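A Larger Group on the Chloro Compound

The source may hold more compounds than are shown below. What is called first, only, known or untested is meant among the compounds shown, and "the series" means these compounds.

In a functional assay on PC-3 cells (Homo sapiens) for antiproliferative activity, read by MTT assay, with a stated time of 48 h (a higher number here means a weaker inhibitor, a lower number a stronger inhibitor), compound 1 `CN1C(=O)C(O)(Cc2nnn[nH]2)c2ccccc21` gives 44800 nM and compound 2 `CN1C(=O)C(O)(Cc2nnn[nH]2)c2cc(F)ccc21` gives 38200 nM. Compound 3 `CN1C(=O)C(O)(Cc2nnn[nH]2)c2cc(Cl)ccc21` returns only a limit, > 100000 nM, and not a number.

Compound 4 `O=C1N(Cc2ccc(Br)cc2)c2ccc(Cl)cc2C1(O)Cc1nnn[nH]1` keeps the chloro group of compound 3 and differs in one place: 4-bromophenyl in place of hydrogen on a saturated chain carbon bound to an amide-type nitrogen in a ring. In other words, methyl gives way to 4-bromobenzyl.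

The measured steps all concern an aromatic carbon. Fluoro in place of hydrogen gives a 1.2-fold lower number from compound 1 to compound 2 (0.07 log units; within the scatter). Chloro in place of hydrogen gives an at least 2.2-fold higher number from compound 1 to compound 3 (0.34 log units; beyond the scatter), and chloro in place of fluoro gives an at least 2.6-fold higher number from compound 2 to compound 3 (0.41 log units; beyond the scatter). None of these steps touches the place that changes now, so they offer only indirect guidance on its size.

The expectation is therefore a modest move to a lower number, back towards compound 1 at 44800 nM. For compound 4, a result that is again only a limit remains possible. The estimated change is an at least 3.3-fold lower number from compound 3 to compound 4 (0.52 log units; beyond the scatter). For compound 4 the expected value is 30000 nM, with an estimated range of 8000 nM to 90000 nM.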

Compound 4, half-maximal inhibitory concentration: 87900 nM
Estimate against measurement, compound 4: 2.9-fold (0.47 log units) below; the range from low to high includes it.
By their numbers in this assay, from the lowest: compounds 2, 1 and 4 (each within the scatter of the next, the first and the last beyond it). At a limit, above all of these: compound 3.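

This is the first change shown at the saturated chain carbon bound to an amide-type nitrogen in a ring, and it replaces a limit with a measured number: in this assay, methyl giving way to 4-bromobenzyl yields an at least 1.1-fold lower number from compound 3 to compound 4 (0.05 log units; that floor lies within the scatter). Compound 3 is known only through a limit, so only a floor can be given for this step and its true size stays unknown, because of this: the limit of > 100000 nM in this assay, at which 1 of the 4 values shown sits.

What can be said is that a measurable result survives this much larger group on the chloro compound, with compound 4 at 87900 nM.

As far as these compounds go, whether 4-bromobenzyl would act the same way on compound 1 or compound 2, without the chloro group, stays open. Also open, from the compounds shown here alone, is what plain benzyl, a longer chain, or a group bearing an amine or a carboxylic acid would give at this place.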